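Replacing a Dimethylsulfamoyl Amide with a Difluoroacetamide

The source may hold more compounds than are shown below. What is called first, only, known or untested is meant among the compounds shown, and "the series" means these compounds.

Compound 1 `O=C1O[C@@H](CO)CN1c1ccc(-n2cc(-c3ccccn3)cn2)c(F)c1`: 1.67
Compound 2 `O=C1O[C@@H](Cn2ccnn2)CN1c1ccc(-n2cc(-c3ccccn3)cn2)c(F)c1`: 2
Compound 3 `CN(C)S(=O)(=O)NC[C@H]1CN(c2ccc(-n3cc(-c4ccccn4)cn3)c(F)c2)C(=O)O1`: 1.38

In a physicochemical assay for lipophilicity, read by HPLC, measured as octanol-water partition (on this read-out higher numbers stand for higher lipophilicity and lower numbers for lower lipophilicity), compound 3 stands lowest of the three. Compound 1 lies closest, with a number 0.29 log units lower from compound 1 to compound 3 (within the scatter), and compound 2 furthest, with a number 0.62 log units lower from compound 2 to compound 3 (beyond the scatter). Compound 4 `O=C(NC[C@H]1CN(c2ccc(-n3cc(-c4ccccn4)cn3)c(F)c2)C(=O)O1)C(F)F` differs from compound 3 by (difluoromethyl)carbonyl in place of dimethylsulfamoyl on an amine nitrogen. Going by the values given here, no measured step exchanges the group on that amine nitrogen; the steps that bear on this position only swap the whole side group on the chain carbon, and they span a modest range. The change from compound 3 to compound 4 is therefore expected to be small, as a number 0.22 log units higher from compound 3 to compound 4 (within the scatter), in the direction of slightly higher lipophilicity. Compound 4 is estimated at 1.6, between 1.2 and 2.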

Compound 4, partition coefficient: 1.9
Compound 4: middle estimate off by 0.30 log units, on the low side, and the stated range covers the measured number.
By their numbers in this assay, from the lowest: compounds 3, 1, 4 and 2 (each within the scatter of the next, the first and the last beyond it).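

In this assay, going by these compounds alone, exchanging only the group on the amine nitrogen gives a step beyond the scatter (a number 0.52 log units higher from compound 3 to compound 4 (beyond the scatter)), whereas the earlier steps had swapped the whole side group. Compound 4 is not separated from either of the other side groups, since both (a number 0.10 log units lower from compound 2 to compound 4 (within the scatter)) and (a number 0.23 log units higher from compound 1 to compound 4 (within the scatter)) lie within the scatter. Nothing available explains the step from the dimethylsulfamoyl to the (difluoromethyl)carbonyl group.

Open, from the compounds shown here alone, is how a plain acetyl or a trifluoroacetyl group on that amine nitrogen would read, and whether a methanesulfonyl group would read like dimethylsulfamoyl.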